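Thiophen-2-yl in place of propyl on a carbonyl carbon

The source may hold more compounds than are shown below. What is called first, only, known or untested is meant among the compounds shown, and "the series" means these compounds.

In a functional assay on U2OS cells (Homo sapiens) for antiproliferative activity, read by MTT assay, with a stated time of 72 h (a lower number here means a stronger inhibitor, a higher number a weaker inhibitor), compound 1 `O=C(CSc1cccc(O)c1)Nc1ccc2nc(NC(=O)c3ccc(F)cc3)sc2c1` gives 5120 nM and compound 2 `CCCC(=O)Nc1nc2ccc(NC(=O)CSc3cccc(O)c3)cc2s1` gives 10100 nM as its value, so the two stand within the scatter of each other. Compound 3 `O=C(CSc1cccc(O)c1)Nc1ccc2nc(NC(=O)c3cccs3)sc2c1` carries thiophen-2-yl in place of propyl on a carbonyl carbon. Among the compounds with values here, the only measured step bearing on this is a 2.0-fold higher number from compound 1 to compound 2 (0.30 log units; within the scatter) for propyl in place of 4-fluorophenyl, and it stays within the scatter. A small move to a lower number in this assay is therefore expected, no larger than the scatter. The estimated step is a 1.7-fold lower number from compound 2 to compound 3 (0.23 log units; within the scatter) in this series. Compound 3 is expected at 6000 nM as its value, within a range of 2500 nM to 13000 nM on this estimate.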

Compound 3, half-maximal inhibitory concentration: 63000 nM
Estimate against measurement, compound 3: 11-fold (1.02 log units) below; measured number outside the range, above it.
By their numbers in this assay, from the lowest: compounds 1 and 2 (each within the scatter of the next); then compound 3.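

In this assay this carbonyl position proves sensitive to the group it carries: thiophen-2-yl gives a 6.2-fold higher number from compound 2 to compound 3 (0.80 log units; beyond the scatter) and a 12-fold higher number from compound 1 to compound 3 (1.09 log units; beyond the scatter) while propyl and 4-fluorophenyl stand within the scatter of each other. An aromatic ring as such does not go with the weakening, since compound 1 also carries one and stands within the scatter of compound 2. No evidence to hand explains the thiophen-2-yl result.

Open, going by these compounds, is whether the weakening extends to furan-2-yl or stays with the sulfur-containing ring. Also open, on these data alone, is how a longer chain or a pyridin-3-yl group would compare with propyl and 4-fluorophenyl.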